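Swapping a Thiophene for a Dichlorophenyl on the Alkene

The source may report more compounds than this note shows. Statements on the series, on what has been measured and on what is new or still open speak of the compounds shown alone.

The series shares an enone core bearing a sulfur substituent on one alkene carbon and an aryl group on the other. Compound 1 is `Cc1ccc(CS/C(=C/c2ccc(C)s2)C(=O)c2ccc(Cl)cc2)cc1`; in a functional assay on DU-145 cells (Homo sapiens) for inhibition, read by trypan blue exclusion, with a stated time of 96 h (on this read-out higher numbers stand for weaker inhibition of growth and lower numbers for stronger inhibition of growth), compound 1 gives 50000 nM, the highest of the two numbers reported. Its nearest neighbour is compound 2, `Cc1ccc(/C=C(/Sc2ccc(F)cc2)C(=O)c2ccc(Cl)cc2)s1`, which in this assay gives 25000 nM; the change a 2.0-fold lower number from compound 1 to compound 2 (0.30 log units; within the scatter). Compound 3, `Cc1ccc(CS(=O)(=O)/C(=C/c2c(O)cc(O)cc2O)C(=O)c2ccc(Cl)cc2)cc1`, reaches only a limit in this assay, > 100000 nM, as noted in the limit of > 100000 nM in this assay, at which 1 of the 3 values shown sits.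

Compound 4, `Cc1ccc(CS/C(=C/c2cc(Cl)cc(Cl)c2)C(=O)c2ccc(Cl)cc2)cc1`, differs from compound 1 in one place: 3,5-dichlorophenyl in place of 5-methylthiophen-2-yl on a double-bonded chain carbon bound to a double-bonded chain carbon. Among the compounds with values here, no measured step alters the aryl group on this alkene carbon; the only single-point step, from compound 1 to compound 2, concerns the sulfur substituent and stays within the scatter. Within the data shown here, there is thus no direct precedent for the present change, and the expected step is estimated as a 1.3-fold lower number from compound 1 to compound 4 (0.10 log units; within the scatter), with no direction asserted beyond the scatter. Compound 4 is therefore estimated to give 40000 nM in this assay, within a range from 10000 nM to 100000 nM.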

Compound 4, concentration for 50% growth inhibition: 10000 nM
Estimate against measurement, compound 4: 4.0-fold (0.60 log units) above, and the stated range covers the measured number.
By their numbers in this assay, from the lowest: compound 4; then compounds 2 and 1 (each within the scatter of the next). At a limit, above all of these: compound 3.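

Within the compounds shown, this alkene carbon is the first position where a single change moves the number beyond the scatter: in this assay, the exchange gives a 5.0-fold lower number from compound 1 to compound 4 (0.70 log units; beyond the scatter), whereas the one earlier step, at the sulfur substituent, gives a 2.0-fold lower number from compound 1 to compound 2 (0.30 log units; within the scatter). The exchange alters several things at once, since the five-membered ring with its sulfur and methyl group leaves and a six-membered carbon ring carrying two chlorines enters, so this one step cannot assign the change in number to any one of these features. The measurements shown offer no evidence that bears on why this exchange lowers the number.

On these data alone, it remains open whether an unsubstituted phenyl or a phenyl with a single chlorine on this alkene carbon would give the same step, and whether a methoxy group, an amine or a carboxylic acid in place of the chlorines would preserve it. As far as these compounds go, it is equally open whether 3,5-dichlorophenyl would have a similar effect alongside the 4-fluorophenyl on the sulfur of compound 2, since the step has been read only with the 4-methylbenzyl group of compound 1 on that sulfur.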